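Swapping a sulfonyl group for a cyclic urea

This account rests on a few compounds, and the source may have more. Where it says the series, first, only, none or still open, it means among the compounds named here.

Compound 1 `CCOC(=O)N(Cc1ccccc1C(C)C)[C@H]1CCNC1` gives 3340 nM in an assay on HEK293 cells for inhibition of sodium-dependent dopamine transporter (Homo sapiens); a higher number here means a weaker inhibitor, a lower number a stronger inhibitor.
Compound 2 `CCOC(=O)N(Cc1ccccc1SC)[C@H]1CCNC1` gives "not determined" (no result reported) in this assay.
Compound 3 `CC(C)S(=O)(=O)N(Cc1ccccc1-c1ccccc1)[C@H]1CCNC1` gives 2700 nM in this assay.

Two numbers exist in this assay. Compound 3 has the lower of them, but its gap to compound 1 is within the usual scatter, so the two cannot be told apart, and compound 2 adds no number at all. The next compound, compound 4 `O=C(N1CCCC1)N(Cc1ccccc1-c1ccccc1)[C@H]1CCNC1`, keeps the core of compound 3 and changes only the group on the amine nitrogen: (pyrrolidin-1-yl)carbonyl in place of isopropylsulfonyl on an amine nitrogen. Within the data shown here, no two measured compounds differ from each other in only one place, so there is no comparison from which the size of such a swap could be read. With nothing in the data pointing either way, the expectation is a change no larger than the scatter, expressed as a 1.1-fold higher number from compound 3 to compound 4 (0.05 log units; within the scatter). Compound 4 is therefore expected to give about 3000 nM in this assay, with a plausible range from 1000 nM to 10000 nM.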

Compound 4, inhibition constant: 4190 nM
Beside the measured number, compound 4's estimate is 1.4-fold (0.15 log units) below it; low and high end bracket the measured number.
By their numbers in this assay, from the lowest: compounds 3, 1 and 4 (each within the scatter of the next).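

Among these compounds, this is the first comparison in which only one group changes, so it gives a direct reading of the group on the amine nitrogen: in this assay the swap gives a 1.6-fold higher number from compound 3 to compound 4 (0.19 log units; within the scatter). On the core of compound 3, isopropylsulfonyl and (pyrrolidin-1-yl)carbonyl therefore cannot be told apart in this assay, even though the entering group brings a five-membered non-aromatic ring and one hydrogen-bond acceptor where the leaving group has two. No supporting measurement bears on why these two groups give numbers within the scatter of each other.

As far as these compounds go, it remains open whether a group of another kind on this nitrogen, such as a simple amine chain or a carboxylic acid, would move the number beyond the scatter. From the compounds shown here alone, it is also open whether the same swap would give a similar step on a different core.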